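Swapping Methyl for Methoxy on a Weak Antiproliferative

This account rests on a few compounds, and the source may have more. Where it says the series, first, only, none or still open, it means among the compounds named here.

Of the compounds shown here, three sharing one core have been tested in a functional assay on A549 cells (Homo sapiens) for antiproliferative activity, with a stated time of 5 days; a higher number here means a weaker inhibitor, a lower number a stronger inhibitor. Compound 1 `Cc1ccc(-n2nc(-c3ccc4ccccc4c3)nc2N2C(=O)C(C)OC23C=CC(=O)C=C3)cc1` gives 1210 nM, the highest number of the three. Compound 2 `CC1CN(c2nc(-c3ccc4ccccc4c3)nn2-c2ccccc2)C2(C=CC(=O)C=C2)O1` gives 320 nM in this assay, and compound 3 `O=C1C=CC2(C=C1)OCC(=O)N2c1nc(-c2cccc(Cl)c2)nn1-c1ccccc1` gives 25.2 nM in this assay; both gaps from compound 1 lie beyond the scatter. Compound 4 `COc1ccc(-n2nc(-c3ccc4ccccc4c3)nc2N2C(=O)C(C)OC23C=CC(=O)C=C3)cc1` has not yet been measured. It differs from compound 1 in one place: methoxy in place of methyl on an aromatic carbon. Within the data shown here, no measured pair here shows this same change, so there is no direct precedent. Such a small exchange is expected to move the number only slightly, and the estimated step is a 1.3-fold lower number from compound 1 to compound 4 (0.11 log units; within the scatter), a size that would sit within the usual scatter. Compound 4 is therefore expected to give about 950 nM in this assay, with a range from 350 nM to 2600 nM.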

Compound 4, half-maximal inhibitory concentration: 860 nM
The estimate for compound 4 lay 1.1-fold (0.04 log units) above the measured number; measured number inside the range.
By their numbers in this assay, from the lowest: compound 3; then compound 2; then compounds 4 and 1 (each within the scatter of the next).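

In this assay the exchange of 4-methylphenyl for 4-methoxyphenyl gives a 1.4-fold lower number from compound 1 to compound 4 (0.15 log units; within the scatter) and this step lies within the scatter, so the two compounds cannot be told apart. At this position, then, adding an oxygen that counts as a hydrogen-bond acceptor brings no readable difference. Nothing measured here ties this result to any property of either group.

Still open, from the compounds shown here alone, is whether an amine, a carboxylic acid or a longer chain at this same position would move the number beyond the scatter. Also open, going by these compounds, is whether the same exchange would give a similar result on compounds with other substituents elsewhere.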